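The compounds below may be only part of what the source reports. "The series", "measured", "known", "first", "only" and "open" are said of these compounds alone.

Among the measured compounds shown here, in a functional assay on HeLa cells (Homo sapiens) for antiproliferative activity, read by sulforhodamine B assay, with a stated time of 72 h (on this read-out lower numbers stand for stronger inhibition and higher numbers for weaker inhibition), three compounds built on a shared core have numbers so far. Compound 1 (`C(=C/c1ccccc1)\C(=N\Nc1nncc2ccccc12)c1ccccc1`) gives 1.4 nM and compound 3 (`O=S(=O)(Nc1ncccn1)c1ccc(Nc2nncc3ccccc23)cc1`) gives 14 nM. Compound 2 (`S=C(NNc1nncc2ccccc12)Nc1ccccc1`) reads 39 nM and so stands highest of the three, which makes it the weakest inhibitor of this small set.

Compound 4 (`COc1ccc(NC(=S)NNc2nncc3ccccc23)cc1`) carries a single change relative to compound 2 (methoxy in place of hydrogen on an aromatic carbon), namely methoxy in place of hydrogen on an aromatic carbon. For the measured compounds named here, no measured pair differs in one place only, so nothing here shows directly what this change does in this assay on its own. The expectation is therefore a small shift, with no step beyond the scatter and a slight lean towards a lower number. That lean rests only on compound 1 at 1.4 nM showing that this set can reach numbers well under that of compound 2. The estimate means a 1.3-fold lower number from compound 2 to compound 4 (0.11 log units; within the scatter) as the expected step. For compound 4 the estimated value is 30 nM with an expected range from 10 nM to 90 nM in this read-out.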

Compound 4, half-maximal inhibitory concentration: 38 nM
For compound 4 the middle estimate is 1.3-fold (0.10 log units) below the measured one, within the range that was stated.
By their numbers in this assay, from the lowest: compound 1; then compound 3; then compounds 4 and 2 (each within the scatter of the next).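

In this assay, among the compounds shown here, methoxy in place of hydrogen on an aromatic carbon, para to a large group, gives a 1.0-fold lower number from compound 2 to compound 4 (0.01 log units; within the scatter) and is the first comparison here between compounds that differ in one place. Compound 2 and compound 4 therefore read alike, so this position accepts a methoxy group with no step beyond the scatter, and the added oxygen and carbon bring no measurable gain in this assay. No outside measurement bears on this result, so the data give no explanation for it.

As far as these compounds go, it remains open whether a different group at the same place, such as an amine, a carboxylic acid or a longer chain, would also read alike. From the compounds shown here alone, it is equally open whether methoxy on another carbon of this ring would leave the number where it stands.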